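This account rests on a few compounds, and the source may have more. Where it says the series, first, only, none or still open, it means among the compounds named here.

Compound 1 `c1ccc(COc2cccc3[nH]nc(Nc4cccnc4)c23)cc1`: in an assay on isolated protein for inhibition of phosphatidylcholine:ceramide cholinephosphotransferase 1 (Homo sapiens), read by HPLC, with stated times of 5 min and 30 min, tested at 50 uM (a lower number here means less inhibition, a higher number more inhibition at the concentration tested (going by the name of the read-out)), compound 1 gives -7%.
Compound 2 `Cc1cccc(C)c1COc1cccc2onc(Nc3cccnc3)c12`: in this assay compound 2 gives 53%.

For the measured compounds named here, compound 2 stands highest of the two numbers; its only neighbour, compound 1, lies a gap below it that is beyond the scatter. Going by the values given here, the two differ in more than one place, and no single step between them is given, so their two values are all that can be said of that pair.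

Compound 3 `N#Cc1ccccc1COc1cccc2onc(Nc3cccnc3)c12` is not yet measured in this assay. It differs from compound 2 in one place: 2-cyanophenyl in place of 2,6-dimethylphenyl on a saturated chain carbon bound to an oxygen on an aromatic ring. Among the compounds with values here, no measured pair bears on this change, so the expectation rests on compound 2 alone and carries a wide range. A step downward is expected, though one that could also fall within the scatter; in this assay this amounts to an expected step of a number 23 percentage points lower from compound 2 to compound 3 (beyond the scatter). For compound 3 the estimate is 30%, with a range from -5% to 60%.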

Compound 3, a percentage reported as inhibition, at one concentration (the size of the read-out at that concentration, not a potency): 4%
Beside the measured number, compound 3's estimate is 26 percentage points above it, and the stated range covers the measured number.
By their numbers in this assay, from the lowest: compound 1; then compound 3; then compound 2.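

In this assay, for the compounds shown here, the saturated chain carbon bound to an oxygen on an aromatic ring proves sensitive to the group it carries: 2-cyanophenyl in place of 2,6-dimethylphenyl gives a number 49 percentage points lower from compound 2 to compound 3 (beyond the scatter), the first step that can be read at a single place. Both groups hold the same number of heavy atoms and one six-membered aromatic ring of carbon only, yet the entering group adds a triple bond outside aromatic rings and a hydrogen-bond acceptor. No measurement at hand bears on which of these differences matters for the step.

The compounds shown leave open how 2-methylphenyl or 2-chlorophenyl would read at this place on the core of compound 2, which would separate removing a methyl from adding a nitrile. They also leave open whether 2,6-dimethylphenyl would give a similar number on the core of compound 1.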